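Compound 2 and the step from acetyl to benzoyl

The source may report more compounds than this note shows. Statements on the series, on what has been measured and on what is new or still open speak of the compounds shown alone.

Compound 1 `O=C(Nc1n[nH]c2c1CN(C(=O)c1ccccc1)C2)c1ccc(F)cc1`: 3190 nM
Compound 2 `CC(=O)n1nc(NC(=O)c2ccccc2)c2c1CN(C(=O)c1ccccc1)C2`: 580 nM

In a functional assay on HCT-116 cells (Homo sapiens) for cytotoxicity, read by sulforhodamine B assay, with a stated time of 48 h (a higher number here means a weaker inhibitor, a lower number a stronger inhibitor), compound 2 holds the lower of the two numbers at 580 nM, while compound 1 gives 3190 nM, a gap beyond the usual scatter. These two compounds differ in more than one place, so their gap cannot be tied to any single change.

The next compound is compound 3 `O=C(Nc1nn(C(=O)c2ccccc2)c2c1CN(C(=O)c1ccccc1)C2)c1ccccc1`. It departs from compound 2 by phenyl in place of methyl on a carbonyl carbon, with phenyl in place of methyl on a carbonyl carbon, which turns acetyl into benzoyl. Among the measured compounds shown here, no measured pair shows what this change does, so the expectation is cautious: no shift beyond the scatter, with only a slight lean towards a higher number in this assay. The expected step is a 1.2-fold higher number from compound 2 to compound 3 (0.08 log units; within the scatter). Compound 3 is estimated at 700 nM, with an expected range from 200 nM to 2400 nM.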

Compound 3, half-maximal inhibitory concentration: 1400 nM
For compound 3 the middle estimate is 2.0-fold (0.30 log units) below the measured one; the range from low to high includes it.
By their numbers in this assay, from the lowest: compound 2; then compound 3; then compound 1.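

Among the compounds shown here, this gives the first measured reading of this position. On a carbonyl carbon whose other neighbour is an aromatic nitrogen, phenyl in place of methyl, which turns acetyl into benzoyl, gives a 2.4-fold higher number from compound 2 to compound 3 (0.38 log units; beyond the scatter) in this assay. The step is modest but beyond the scatter, so the position is not indifferent to this change, and acetyl holds the lower number of the pair. Nothing at hand explains the step, which rests on this single pair.

As far as these compounds go, it remains open whether a longer chain such as propyl, or a phenyl bearing an amine or a carboxylic acid, on this carbonyl carbon would stand nearer to acetyl or to benzoyl. One pair also cannot show whether the step keeps its size and direction when other parts of the compound change.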